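The source may report more compounds than this note shows. Statements on the series, on what has been measured and on what is new or still open speak of the compounds shown alone.

Measured in a functional assay on DU-145 cells (Homo sapiens) for antiproliferative activity, read by WST assay, with a stated time of 48 h, tested at 10 uM; on this read-out lower numbers stand for a weaker effect and higher numbers for a stronger effect at the one concentration tested:
Compound 1 `Cc1ccc2[nH]c(-n3[nH]c(C)c(Cc4ccccc4)c3=O)nc2c1`: 54%
Compound 2 `Cc1ccc2[nH]c(-n3[nH]c(C)c(C)c3=O)nc2c1`: 19%

Within the data shown here, compound 2 stands at the lower of the two numbers, with compound 1 the only neighbour and well beyond the scatter above it. Compound 3 `Cc1ccc2[nH]c(-n3[nH]c(C)c(Cc4ccc(Cl)cc4)c3=O)nc2c1` is not yet measured; it differs from compound 2 by 4-chlorophenyl in place of hydrogen on a saturated chain carbon bound to an aromatic carbon. Among the measured compounds shown here, the one measured step that bears on this is a number 35 percentage points lower from compound 1 to compound 2 (beyond the scatter), where a phenyl group at this place was removed. Putting a 4-chlorophenyl group back is expected to reverse that loss, giving an estimated rise of a number 36 percentage points higher from compound 2 to compound 3 (beyond the scatter). Compound 3 is therefore estimated at 55%, expected within 35% to 75%.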

Compound 3, a percentage reported as inhibition, at one concentration (the size of the read-out at that concentration, not a potency): 46%
Compound 3: middle estimate off by 9 percentage points, on the high side, within the range that was stated.
By their numbers in this assay, from the lowest: compound 2; then compounds 3 and 1 (each within the scatter of the next).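

In this assay, the 4-chlorophenyl group on a saturated chain carbon bound to an aromatic carbon also brings a gain, a number 27 percentage points higher from compound 2 to compound 3 (beyond the scatter). So the gain at this place does not depend on an unsubstituted phenyl ring, and chloro in place of hydrogen on the ring gives a number 8 percentage points lower from compound 1 to compound 3 (within the scatter). Nothing available explains either result.

On these data alone, whether this place needs a ring at all, or a longer chain such as butyl would serve, remains open. So does the effect of a methoxy group or an amine on the ring in place of chloro.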